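Hydroxyphenyl pyridines: thiophene for pyridyl exchange

A few compounds are considered here, and "the series" means these few. Any claim that something is new, unique, unknown or untested is made for them only; others in the source may bear on it.

Measured compounds in the series:
compound 1 `Oc1ccc(-c2cc(-c3ccncc3)nc(-c3ccc(Cl)cc3)c2)cc1` – "not determined" (no result reported)
compound 2 `Oc1cccc(-c2cc(-c3ccncc3)nc(-c3ccc(Cl)cc3)c2)c1` – 2630 nM

Compound 1 `Oc1ccc(-c2cc(-c3ccncc3)nc(-c3ccc(Cl)cc3)c2)cc1` carries a 4-hydroxyphenyl group on the shared core; in a functional assay on HCT-15 cells (Homo sapiens) for cytotoxicity, read by CCK-8 assay and cell counting, with a stated time of 2 days (on this read-out lower numbers stand for stronger inhibition and higher numbers for weaker inhibition), compound 1 gives "not determined" (no result reported), so no number stands for it. Compound 2 `Oc1cccc(-c2cc(-c3ccncc3)nc(-c3ccc(Cl)cc3)c2)c1` differs from compound 1 only in the placement of the hydroxyl on the phenyl ring, and in this assay compound 2 gives 2630 nM. Among the compounds with values here, no pair of measured compounds differs in one place, so no step size is known within this set.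

Compound 3 `Oc1ccc(-c2cc(-c3ccc(Cl)cc3)nc(-c3cccs3)c2)cc1` is not yet measured. It differs from compound 1 as follows: thiophen-2-yl in place of pyridin-4-yl on an aromatic carbon. The nearest reference is compound 2 with 2630 nM, which is only a relative of compound 1 and not its direct partner. Without any measured step for the exchange of a pyridin-4-yl for a thiophen-2-yl group, the direction of the change in this assay cannot be read from the data; a step beyond the scatter in either direction is possible, and weaker inhibition is judged somewhat more likely.

Compound 3 is estimated at 4000 nM in this assay, within a range of 800 nM to 20000 nM.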

Compound 3, half-maximal inhibitory concentration: 6470 nM
Compound 3: the middle estimate sits 1.6-fold (0.21 log units) below what was measured; low and high end bracket the measured number.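

No new step can be read between compound 1 and compound 3: in this assay compound 1 gives "not determined" (no result reported) and compound 3 gives 6470 nM without a numerical partner. The compounds shown leave open how exchanging pyridin-4-yl for thiophen-2-yl changes the read-out. No supporting evidence bears on this result.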